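The source may report more compounds than this note shows. Statements on the series, on what has been measured and on what is new or still open speak of the compounds shown alone.

Measured compounds:
compound 1 `COc1cccc(NC(=O)N[C@H]2CC[C@H](Oc3ccc(F)cc3)CC2)c1` — 14000 nM
compound 2 `O=C(Nc1cccc(Br)c1)N[C@H]1CC[C@H](Oc2ccc(F)cc2)CC1` — 6200 nM

In a functional assay on CRL2813 cells (Homo sapiens) for cytotoxicity, read by sulforhodamine B assay, with a stated time of 5 days (on this read-out lower numbers stand for stronger inhibition and higher numbers for weaker inhibition), compound 2 gives 6200 nM, the lowest of the two numbers; compound 1 gives 14000 nM. Among the compounds with values here, the one measured step, a 2.3-fold lower number from compound 1 to compound 2 (0.35 log units; beyond the scatter), came with bromo in place of methoxy on an aromatic carbon. Compound 3 `COc1ccc(NC(=O)N[C@H]2CC[C@H](Oc3ccc(F)cc3)CC2)cc1` is not yet measured; it differs from compound 2 by 4-methoxyphenyl in place of 3-bromophenyl on an amide-type nitrogen. Since the methoxy-bearing compound 1 gave 14000 nM, a return toward that number is expected, a modest rise rather than a fall. For compound 3 the estimate is 12000 nM, within 5000 nM to 30000 nM, meaning an expected step of a 1.9-fold higher number from compound 2 to compound 3 (0.29 log units; within the scatter).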

Compound 3, half-maximal inhibitory concentration: > 20000 nM
Compound 3 gave a limit, no number (the forecaster's own chance of this, stated with the estimate: 10%); at least 1.6-fold (0.22 log units) between middle value and limit.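

In this assay compound 3 gives > 20000 nM, which is a limit of the assay and not a number. On the amide-type nitrogen, the change to 4-methoxyphenyl gives an at least 3.2-fold higher number from compound 2 to compound 3 (0.50 log units; beyond the scatter), so this replacement does not retain the lower number seen with 3-bromophenyl. The comparison with 3-methoxyphenyl gives an at least 1.4-fold higher number from compound 1 to compound 3 (0.15 log units; that floor lies within the scatter), so these two methoxy placements are not separated.

From the compounds shown here alone, how far compound 3 lies past its limit remains open. Also open, going by these compounds, is how an amine or a carboxylic acid on this phenyl ring would read here.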